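The compounds below may be only part of what the source reports. "The series", "measured", "known", "first", "only" and "open" are said of these compounds alone.

Compound 1 `Cc1oc(-c2c(Br)cccc2Br)nc1CN1CCC(C(=O)NCCCN2C[C@H](C)C[C@H](C)C2)CC1`: 62.4 ug/mL
Compound 2 `COc1cccc(Cl)c1-c1nc(CN2CCC(C(=O)NCCCN3C[C@H](C)C[C@H](C)C3)CC2)c(C)o1`: > 76 ug/mL

In a physicochemical assay for solubility, in phosphate buffer, measured as kinetic solubility, at pH 7.4 (a lower number here means a less soluble compound, a higher number a more soluble compound), compound 2 has no exact number: > 76 ug/mL is a limit of the assay. the limit of > 76 ug/mL in this assay, at which 1 of the 2 values shown sits, is the only such case here. Compound 3 `Cc1ccc(-c2nc(CN3CCC(C(=O)NCCCN4C[C@H](C)C[C@H](C)C4)CC3)c(C)o2)cc1C` carries 3,4-dimethylphenyl in place of 2-chloro-6-methoxyphenyl on an aromatic carbon. Going by the values given here, the only measured step touching this group is an at least 1.2-fold higher number from compound 1 to compound 2 (0.08 log units; that floor lies within the scatter), and its floor lies within the scatter, so it gives no firm size or direction. The expected step, an at least 1.1-fold lower number from compound 2 to compound 3 (0.06 log units; that floor lies within the scatter), is none beyond the scatter. For compound 3 the estimated solubility is 65 ug/mL, with an expected range of 30 ug/mL to 95 ug/mL.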

Compound 3, solubility: > 71 ug/mL
Compound 3: only a limit was reported (the forecaster's own chance of this, stated with the estimate: 40%); middle value at least 1.0-fold (0.03 log units) from the limit.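

In this assay compound 3 gives only a limit, so a group with no hydrogen-bond acceptor at this position still reaches a limit of the assay. Replacing 2,6-dibromophenyl with 3,4-dimethylphenyl gives an at least 1.1-fold higher number from compound 1 to compound 3 (0.05 log units; that floor lies within the scatter), which, like the earlier change here, fixes no firm size or direction. The step between compound 2 and compound 3 cannot be read, since both values are limits: the limit of > 71 ug/mL in this assay, at which 1 of the 3 values shown sits.

As far as these compounds go, how far compound 2 and compound 3 actually differ remains open. Also open, from the compounds shown here alone, is whether an amine or a carboxylic acid on this phenyl ring would give a step beyond the scatter.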